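Anticancer screening of a diarylidene diketopiperazine series

The compounds below may be only part of what the source reports. "The series", "measured", "known", "first", "only" and "open" are said of these compounds alone.

Measured compounds:
- compound 1 `COc1ccccc1/C=c1/[nH]c(=O)/c(=C\c2ccccc2OC)n(C)c1=O`: "not active" (no number reported)
- compound 2 `C=CCn1c(=O)/c(=C\c2ccccc2Cl)[nH]c(=O)/c1=C\c1ccccc1OC`: 4600 nM

Going by the values given here, in a functional assay on BGC-823 cells (Homo sapiens) for cytotoxicity, read by CCK-8 assay, with a stated time of 72 h (a higher number here means a weaker inhibitor, a lower number a stronger inhibitor), compound 2 gives 4600 nM, the only numerical value so far. Among the compounds with values here, compound 1 gives "not active" (no number reported) without a number, so no measured step stands beside compound 2. Compound 3 `C=CCn1c(=O)/c(=C\c2ccc(F)c(Br)c2)[nH]c(=O)/c1=C\c1ccccc1OC` differs from compound 2 by 3-bromo-4-fluorophenyl in place of 2-chlorophenyl on a double-bonded chain carbon bound to an aromatic carbon. Within the data shown here, with no measured pair differing in one place, the direction of this change is open. The estimated step from compound 2 to compound 3 is a 1.1-fold higher number from compound 2 to compound 3 (0.04 log units; within the scatter), which is not expected to go beyond the scatter. Compound 3 is accordingly estimated at 5000 nM, with a range from 1500 nM to 16000 nM.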

Compound 3, half-maximal inhibitory concentration: "not active" (no number reported)
Compound 3 has no reported number here; there is nothing to compare the estimate with.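

Going by these compounds alone, with no number for compound 3, no step from compound 2 to compound 3 can be read. Nothing shown explains this result. The compounds shown leave open how the aryl group on the double-bonded chain carbon affects cytotoxicity.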